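The source may report more compounds than this note shows. Statements on the series, on what has been measured and on what is new or still open speak of the compounds shown alone.

Three compounds sharing one core were run in an ADME assay on BJ cells (Homo sapiens) for cytotoxicity, with a stated time of 72 h; on this read-out lower numbers stand for an effect already at smaller amounts and higher numbers for an effect only at larger amounts of compound. Compound 1 `COc1cc2ncnc(-n3nc(-c4ccccn4)nc3N)c2cc1[N+](=O)[O-]` gave only a limit, > 13000 nM, which marks the edge of the measurement rather than a number. Compound 3 `COc1cc2ncnc(-n3nc(N)nc3N)c2cc1OC` also stopped at a limit, > 33000 nM. For compound 2 `Nc1nc(-c2ccccn2)nn1-c1ncnc2cc(N3CCNCC3)c([N+](=O)[O-])cc12` the entry in this assay reads "not determined" (no result reported). Compound 1 therefore stands at one of two limits, with no exact value beside it. Compound 4 `COc1cc2ncnc(-n3nc(-c4ccccn4)nc3N)c2cc1OCCCNC(=O)OC(C)C` differs from compound 1 in a single way: 3-((isopropoxycarbonyl)amino)propoxy in place of nitro on an aromatic carbon. Among the compounds with values here, no measured pair differs in one place, so the size of such a step is unknown. Compound 4 is expected to stay near the limit, with a step that the limit leaves unreadable from compound 1 to compound 4 expected to lie within the usual scatter. The estimate for compound 4 is 20000 nM, between 8000 nM and 50000 nM.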

Compound 4, half-maximal effective concentration: > 13000 nM
Compound 4: only a limit was reported (the forecaster's own chance of this, stated with the estimate: 75%); the middle value lies beyond the limit too.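

In this assay, within the data shown here, compound 1 and compound 4 both stop at a limit, so no step between them can be read. The compounds shown leave open the concentration at which any of them reaches a half-maximal effect.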